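The source may hold more compounds than are shown below. What is called first, only, known or untested is meant among the compounds shown, and "the series" means these compounds.

Measured in a functional assay on HepG2 cells (Homo sapiens) for antiproliferative activity, read by MTT assay, with a stated time of 24 h; a higher number here means a weaker inhibitor, a lower number a stronger inhibitor:
- compound 1 `C=CCOc1ccc2c(=O)c(-c3cc(OC)c(OC)cc3OC)coc2c1`: 3450 nM
- compound 2 `COc1cc(OC)c(-c2coc3cc(OCc4ccc(F)cc4)ccc3c2=O)cc1OC`: 1000 nM

Compound 2 holds the lowest number of the two. Among the measured compounds shown here, the only measured step is a 3.5-fold lower number from compound 1 to compound 2 (0.54 log units; beyond the scatter), with 4-fluorophenyl in place of vinyl, and it is modest. Compound 3 `COc1cc(OC)c(-c2coc3cc(OCc4ccc(Br)cc4)ccc3c2=O)cc1OC` carries bromo in place of fluoro on an aromatic carbon, para to a large group. For the measured compounds named here, no measured step swaps one halogen for another, so that step bears only indirectly. In this assay, no change beyond the scatter is expected, and the estimated step is a 1.1-fold lower number from compound 2 to compound 3 (0.05 log units; within the scatter). For compound 3 the estimated value is 900 nM, with an expected range of 350 nM to 2500 nM.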

Compound 3, half-maximal inhibitory concentration: 1050 nM
The estimate for compound 3 lay 1.2-fold (0.07 log units) below the measured number; the measured number falls inside the stated range.
By their numbers in this assay, from the lowest: compounds 2 and 3 (each within the scatter of the next); then compound 1.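

In this assay, bromo in place of fluoro on an aromatic carbon, para to a large group, gives a 1.1-fold higher number from compound 2 to compound 3 (0.02 log units; within the scatter), so this halogen swap leaves the number within the scatter. 4-bromophenyl in place of vinyl gives a 3.3-fold lower number from compound 1 to compound 3 (0.52 log units; beyond the scatter), so the modest drop from compound 1 is not tied to fluoro alone. No data at hand bear on the cause of either step.

Going by these compounds, whether an amine or a carboxylic acid on this same aromatic carbon would hold the number remains open. So does how a plain benzyl group would compare with compound 2 and compound 3.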